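This account rests on a few compounds, and the source may have more. Where it says the series, first, only, none or still open, it means among the compounds named here.

In a functional assay on HEK293 cells for antagonist activity at P2X purinoceptor 7 (Homo sapiens) (on this read-out higher numbers stand for weaker inhibition and lower numbers for stronger inhibition), compound 3 `Cc1cccc(N2C[C@@H](C(=O)NCc3cccc(C(F)(F)F)c3Cl)N(C)C2=O)n1` gives 79.4 nM, the highest of the three numbers measured. Compound 1 `CN1C(=O)C(F)(F)C[C@H]1C(=O)NCc1cccc(C(F)(F)F)c1Cl` gives 3.98 nM and compound 2 `Cc1ncccc1N1C[C@@H](C(=O)NCc2cccc(C(F)(F)F)c2Cl)N(C)C1=O` gives 5.01 nM in this assay. Within the data shown here, the one measured step that bears on a change at this ring nitrogen, a 16-fold higher number from compound 2 to compound 3 (1.20 log units; beyond the scatter), was large. Compound 4 `CN1C(=O)N(c2nccn2C)C[C@H]1C(=O)NCc1cccc(C(F)(F)F)c1Cl` differs from compound 3 by 1-methyl-1H-imidazol-2-yl in place of 6-methylpyridin-2-yl on an amide-type nitrogen in a ring. Among the measured compounds shown here, no measured pair shows this exact exchange, so the direction can only be inferred from the sensitivity seen in that single step. An intermediate number is therefore expected for compound 4 in this assay, with a step of a 2.6-fold lower number from compound 3 to compound 4 (0.42 log units; beyond the scatter). Compound 4 is estimated at 30 nM, within a range from 8 nM to 120 nM.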

Compound 4, half-maximal inhibitory concentration: 3.98 nM
For compound 4 the middle estimate is 7.5-fold (0.88 log units) above the measured one; measured number below the stated range.
By their numbers in this assay, from the lowest: compounds 1, 4 and 2 (each within the scatter of the next); then compound 3.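

In this assay, 1-methyl-1H-imidazol-2-yl on the amide-type nitrogen brings a 20-fold lower number from compound 3 to compound 4 (1.30 log units; beyond the scatter), so the high number of compound 3 does not extend to every aromatic ring at this position. Against 2-methylpyridin-3-yl the same group gives a 1.3-fold lower number from compound 2 to compound 4 (0.10 log units; within the scatter), which leaves 6-methylpyridin-2-yl as the only one of these three groups that stands apart. No supporting data bear on why this group behaves differently. The compounds shown leave open how a morpholine or a plain phenyl ring would read at this nitrogen, and whether the methyl group on the imidazole matters.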